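Swapping the chlorines for methoxy groups on the ketone side

The source may report more compounds than this note shows. Statements on the series, on what has been measured and on what is new or still open speak of the compounds shown alone.

Compound 1 `COc1cc(-c2cc(/C=C/C(=O)c3ccc(Cl)c(Cl)c3)[nH]n2)cc(OC)c1OC` is the weakest of the three measured compounds in a functional assay on SK-MEL-5 cells (Homo sapiens) for inhibition, read by sulforhodamine B assay, with a stated time of 48 h (a higher number here means a weaker inhibitor of growth, a lower number a stronger inhibitor of growth), where compound 1 gives 13400 nM. Compound 2 `COc1ccc(-c2cc(/C=C/C(=O)c3ccc(N)cc3)[nH]n2)cc1OC` gives 3160 nM, and compound 3 `COc1ccc(-c2cc(/C=C/C(=O)c3cc(OC)c(OC)c(OC)c3)[nH]n2)cc1OC` gives 1580 nM; both gaps to compound 1 lie beyond the scatter. The unmeasured compound 4 `COc1ccc(C(=O)/C=C/c2cc(-c3cc(OC)c(OC)c(OC)c3)n[nH]2)cc1OC` keeps the shared core of compound 1 but differs in one place: 3,4-dimethoxyphenyl in place of 3,4-dichlorophenyl on a carbonyl carbon. Because compound 3, which carries methoxy-bearing rings on both ends, gives 1580 nM, the change is expected to lower the number beyond the scatter, with the step of a 3.4-fold lower number from compound 1 to compound 4 (0.53 log units; beyond the scatter). Compound 4 is therefore estimated to give 4000 nM, with a likely range from 1500 nM to 12000 nM.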

Compound 4, concentration for 50% growth inhibition: 1650 nM
The estimate for compound 4 lay 2.4-fold (0.38 log units) above the measured number, within the range that was stated.
By their numbers in this assay, from the lowest: compounds 3, 4 and 2 (each within the scatter of the next); then compound 1.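

Putting 3,4-dimethoxyphenyl in place of 3,4-dichlorophenyl on a carbonyl carbon gives an 8.1-fold lower number from compound 1 to compound 4 (0.91 log units; beyond the scatter) in this assay with the rest of the molecule unchanged. Among these compounds, this pair is the first to differ in one place, so the step beyond the scatter can be tied to this swap alone, which the earlier compounds could not show. No measurement shown here explains why the number falls.

Going by these compounds, it remains open whether the gain comes from adding the methoxy groups or from removing the chlorines. A plain phenyl or a ring bearing a carboxylic acid at this position could help to separate the two.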